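Amine chain length and solubility in the series

This account rests on a few compounds, and the source may have more. Where it says the series, first, only, none or still open, it means among the compounds named here.

Compound 1 `CCCNC1CC(=O)OC1C(O)C(=O)NC(CC(C)C)C1Cc2cccc(O)c2C(=O)O1`: 1600 ug/mL
Compound 2 `CCCCCNC1CC(=O)OC1C(O)C(=O)NC(CC(C)C)C1Cc2cccc(O)c2C(=O)O1`: 330 ug/mL

In a physicochemical assay for solubility, in phosphate buffer (on this read-out higher numbers stand for higher solubility and lower numbers for lower solubility), compound 2 stands lowest of the two numbers, with compound 1 the nearest and higher. The single step shown, a 4.8-fold lower number from compound 1 to compound 2 (0.69 log units; beyond the scatter), places ethyl in place of hydrogen on the chain at the amine nitrogen. Compound 3 `CCCCCCNC1CC(=O)OC1C(O)C(=O)NC(CC(C)C)C1Cc2cccc(O)c2C(=O)O1` carries methyl in place of hydrogen on a saturated chain carbon, five bonds along the chain from an amine nitrogen, extending that same chain by a methyl beyond compound 2. A further lower number is therefore expected for compound 3, smaller than the ethyl step, as a 2.2-fold lower number from compound 2 to compound 3 (0.34 log units; beyond the scatter). Compound 3 is expected at 150 ug/mL, within 60 ug/mL to 400 ug/mL.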

Compound 3, solubility: 5 ug/mL
For compound 3 the middle estimate is 30-fold (1.48 log units) above the measured one, outside the stated range (below it).
By their numbers in this assay, from the lowest: compound 3; then compound 2; then compound 1.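

In this assay, methyl in place of hydrogen on a saturated chain carbon, five bonds along the chain from an amine nitrogen, gives a far larger step (a 66-fold lower number from compound 2 to compound 3 (1.82 log units; beyond the scatter)) than the earlier ethyl change (a 4.8-fold lower number from compound 1 to compound 2 (0.69 log units; beyond the scatter)), although it adds less to the chain. Across compound 1, compound 2 and compound 3, the number therefore does not fall evenly with chain length, and the full propyl change gives a large step (a 320-fold lower number from compound 1 to compound 3 (2.51 log units; beyond the scatter)). No measurement shown accounts for this uneven fall.

Open, on these data alone, is whether a longer chain would bring a further drop. Also open, as far as these compounds go, is how a hydroxyl or a carboxylic acid on the amine chain would read.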